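The source may report more compounds than this note shows. Statements on the series, on what has been measured and on what is new or still open speak of the compounds shown alone.

Measured so far in a functional assay on MGC-803 cells (Homo sapiens) for cytotoxicity, read by MTT assay, with a stated time of 72 h; a higher number here means a weaker inhibitor, a lower number a stronger inhibitor:
compound 1, `Cc1cc(Nc2ccc(Cl)cc2)nc(SCc2nc3ccccc3[nH]2)n1`, gives 28200 nM.
compound 2, `Cc1cc(N2CCNCC2)nc(SCc2nc3ccccc3[nH]2)n1`, is reported only as a limit of the assay, > 100000 nM.
compound 3, `Cc1cc(NNC(N)=S)nc(SCc2nc3ccccc3[nH]2)n1`, is reported only as a limit of the assay, > 100000 nM.

Compound 3 therefore has no number of its own in this assay; it sits at the limit of > 100000 nM in this assay, at which 2 of the 3 values shown sit, together with compound 2, and the step that the two limits leave unreadable from compound 2 to compound 3 cannot be read. Compound 4 is `Cc1cc(N(C)Cc2ccccc2)nc(SCc2nc3ccccc3[nH]2)n1`; the change from compound 3 is a group of 9 heavy atoms (8 carbon, 1 nitrogen; one six-membered aromatic ring of carbon only) in place of a group of 5 heavy atoms (1 carbon, 3 nitrogen, 1 sulfur; no ring), on an aromatic carbon.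

Within the data shown here, two measured steps bear on it. The step of an at least 3.5-fold higher number from compound 1 to compound 3 (0.54 log units; beyond the scatter) shows that exchanging the aryl-bearing substituent of compound 1 for the open-chain group of compound 3 pushed the value past the limit; the step of an at least 3.5-fold higher number from compound 1 to compound 2 (0.54 log units; beyond the scatter) shows the same for piperazin-1-yl. Compound 4 goes the other way, bringing a six-membered aromatic ring back onto that aromatic carbon, so a step downwards from compound 3 is expected, an at least 2.8-fold lower number from compound 3 to compound 4 (0.45 log units; beyond the scatter), its size not readable from a limit. Compound 4 is expected to give about 35000 nM in this assay, within 10000 nM to 100000 nM.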

Compound 4, half-maximal inhibitory concentration: 31300 nM
The estimate for compound 4 lay 1.1-fold (0.05 log units) above the measured number, within the range that was stated.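

In this assay, benzyl(methyl)amino on this aromatic carbon gives a readable number, with an at least 3.1-fold lower number from compound 3 to compound 4 (0.50 log units; beyond the scatter) and an at least 3.1-fold lower number from compound 2 to compound 4 (0.50 log units; beyond the scatter). Exchanging (4-chlorophenyl)amino for benzyl(methyl)amino gives a 1.1-fold higher number from compound 1 to compound 4 (0.05 log units; within the scatter), so the chlorine and the hydrogen on the linking nitrogen are not needed for a readable number here, and among the compounds shown only those carrying a six-membered aromatic ring of carbon give one, with none going against this. Compound 2 and compound 3 each remain a limit of the assay, and the step between them cannot be read: the limit of > 100000 nM in this assay, at which 2 of the 4 values shown sit.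

As far as these compounds go, whether the aromatic ring or simply the size of the group separates these compounds stays open, and a cyclohexylamino group would address this. From the compounds shown here alone, the effect of a methoxy group or a carboxylic acid on the benzyl ring also remains unknown.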